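The source may hold more compounds than are shown below. What is called first, only, known or untested is meant among the compounds shown, and "the series" means these compounds.

Compound 1 `CCC(CC)Nc1ncnc2c1ncn2C1O[C@H](C(=O)NCc2ccccc2)[C@@H](O)[C@H]1O` and compound 2 `CCC(CC)Nc1ncnc2c1ncn2C1O[C@H](C(=O)NC)[C@@H](O)[C@H]1O` share a core and differ only at the amide nitrogen. In an assay with adenosine receptor A1 (Rattus norvegicus) as the target (a lower number here means a stronger inhibitor, a higher number a weaker inhibitor), compound 1 gives 104 nM, and compound 2 gives 20 nM, the lowest of the two numbers, with a 5.2-fold lower number from compound 1 to compound 2 (0.72 log units; beyond the scatter). Compound 3 `CCNC(=O)[C@H]1OC(n2cnc3c(NC(CC)CC)ncnc32)[C@H](O)[C@@H]1O` carries the change (methyl in place of hydrogen on a saturated chain carbon bound to an amide-type nitrogen). Among the compounds with values here, the one measured step bears on it only loosely: it concerns phenyl leaving, not methyl entering, so it sets no direction for a one-carbon addition. For compound 3 the expected step is therefore a 1.3-fold lower number from compound 2 to compound 3 (0.12 log units; within the scatter), none beyond the scatter, with an estimate of 15 nM and a range of 5 nM to 45 nM.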

Compound 3, half-maximal inhibitory concentration: 1.5 nM
Beside the measured number, compound 3's estimate is 10-fold (1.00 log units) above it, and the stated range ends above it.
By their numbers in this assay, from the lowest: compound 3; then compound 2; then compound 1.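

At the amide nitrogen, a single added carbon has a large effect in this assay: methylcarbamoyl to ethylcarbamoyl gives a 13-fold lower number from compound 2 to compound 3 (1.12 log units; beyond the scatter). Replacing phenyl with methyl on the same saturated chain carbon gives a 69-fold lower number from compound 1 to compound 3 (1.84 log units; beyond the scatter), so adding carbon at this position can lower or raise the number, depending on the group added. Nothing available explains the gain from the added methyl.

Still open, from the compounds shown here alone, is whether a longer chain, such as propyl or butyl, keeps or loses this gain. A branched isopropyl group or a cyclopropyl ring on the amide nitrogen is equally unresolved.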